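Adding a Methoxy Group to a Weak Reductase Inhibitor

A few compounds are considered here, and "the series" means these few. Any claim that something is new, unique, unknown or untested is made for them only; others in the source may bear on it.

Compound 1, `CC(C)c1ccc(Sc2c(/C=C/[C@@H]3C[C@@H](O)CC(=O)O3)c(C3CC3)nc3ccccc23)cc1`, was tested in an assay on isolated protein for inhibition of 3-hydroxy-3-methylglutaryl-coenzyme A reductase (Homo sapiens), read by spectrophotometry (a higher number here means a weaker inhibitor, a lower number a stronger inhibitor), where compound 1 gives 11300 nM. Going by the values given here, of the two compounds measured so far this is the highest number. Its only companion, compound 2, `O=C1C[C@H](O)C[C@@H](/C=C/c2c(C3CC3)nc3ccc(F)cc3c2Sc2ccc(F)cc2)O1`, gives 6930 nM in this assay, and the two values sit within the usual scatter of each other, so neither compound can be called the stronger inhibitor on this evidence.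

Compound 3, `COc1ccc2nc(C3CC3)c(/C=C/[C@@H]3C[C@@H](O)CC(=O)O3)c(Sc3ccc(C(C)C)cc3)c2c1`, differs from compound 1 in a single place: methoxy in place of hydrogen on an aromatic carbon, that is, a methoxy in place of hydrogen on an aromatic carbon. Among the compounds with values here, no measured pair in this set shows the effect of that exact exchange, so there is no reference step to lean on, and the two measured values themselves do not separate beyond the scatter. With nothing pointing in either direction, the change is expected to be small, a 1.3-fold lower number from compound 1 to compound 3 (0.12 log units; within the scatter), and not clearly beyond the scatter. Compound 3 is therefore expected to give about 8500 nM in this assay, with a plausible range from 3000 nM to 25000 nM.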

Compound 3, half-maximal inhibitory concentration: 41300 nM
Beside the measured number, compound 3's estimate is 4.9-fold (0.69 log units) below it, and the stated range ends below it.
By their numbers in this assay, from the lowest: compounds 2 and 1 (each within the scatter of the next); then compound 3.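

In this assay, going by these compounds alone, methoxy in place of hydrogen on this aromatic carbon gives a 3.7-fold higher number from compound 1 to compound 3 (0.56 log units; beyond the scatter), the first exchange in this set whose effect stands clear of the usual scatter, and it moves toward a weaker inhibitor. This carbon, on the six-membered aromatic ring of carbon only within the fused system of two rings, is therefore not indifferent to what sits on it: here, adding a methoxy group with its 2 heavy atoms makes inhibition worse rather than leaving it unchanged. Nothing measured here offers a reason for this step.

With only one exchange at this carbon, the compounds shown cannot tell whether the higher number belongs to methoxy in particular or would follow any group placed there instead of hydrogen. On these data alone, whether a hydroxy group, an amine or the longer ethoxy chain on the same carbon would shift the number as far, less far or not at all remains open, as does the effect of methoxy on the other carbons of that ring.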